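A few compounds are considered here, and "the series" means these few. Any claim that something is new, unique, unknown or untested is made for them only; others in the source may bear on it.

Measured compounds in an ADME assay on HEp-2 cells (Homo sapiens) for cytotoxicity, read by MTT assay, with a stated time of 60 h; on this read-out higher numbers stand for lower toxicity in this test and lower numbers for higher toxicity in this test:
Compound 1 `Cc1c(Br)cc2c(nc3n2[C@H]2OC[C@@H](OCc4ccccc4)[C@H]2OC3)c1Br` gives 25600 nM in this assay.
Compound 2 `COc1c(Cl)cc2c(nc3n2[C@H]2OC[C@@H](O)[C@H]2OC3)c1Cl` gives 411000 nM in this assay.
Compound 3 `COc1c(Br)cc2c(nc3n2[C@H]2OC[C@@H](O)[C@H]2OC3)c1Br` gives 259000 nM in this assay.

Among these three, compound 1 stands lowest. Compound 3 gives the nearest higher number and compound 2 the furthest, and both gaps lie beyond the usual scatter. Among the measured compounds shown here, no two of the measured compounds differ in only one place, so no single measured step is available as a yardstick.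

Compound 4 `Cc1c(Br)cc2c(nc3n2[C@H]2OC[C@@H](OS(C)(=O)=O)[C@H]2OC3)c1Br` differs from compound 1 in one place: methylsulfonyl in place of benzyl on an oxygen on a saturated carbon. For the measured compounds named here, compound 1, the only measured compound carrying a benzyl on an oxygen on a saturated carbon, is the one with the lowest number, while the two compounds with a free hydroxyl at that oxygen sit far higher. On that basis the number for compound 4 is expected to move upward, toward the region of compounds 2 and 3, though with considerable uncertainty: the expected step is a 3.1-fold higher number from compound 1 to compound 4 (0.49 log units; beyond the scatter). The estimate for compound 4 is 80000 nM, with a range from 25000 nM to 300000 nM.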

Compound 4, half-maximal cytotoxic concentration: 15600 nM
Estimate against measurement, compound 4: 5.1-fold (0.71 log units) above, and the stated range ends above it.
By their numbers in this assay, from the lowest: compounds 4 and 1 (each within the scatter of the next); then compounds 3 and 2 (each within the scatter of the next).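

Among the compounds shown here, the swap of benzyl for methylsulfonyl on an oxygen on a saturated carbon gives the first single-place comparison in this assay, and it amounts to a 1.6-fold lower number from compound 1 to compound 4 (0.22 log units; within the scatter). This assay therefore does not separate the two groups at this position on the core of compound 1, even though the six-membered aromatic ring of benzyl leaves and methylsulfonyl brings in two hydrogen-bond acceptors. Nothing measured here accounts for the two compounds reading alike.

On these data alone, it remains open how a free hydroxyl would read on the core of compound 1, as compound 2 and compound 3 carry one but differ from compound 1 in more than one place. Also open, as far as these compounds go, is how an acetyl group or a longer alkyl chain on that oxygen would read.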